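The source may report more compounds than this note shows. Statements on the series, on what has been measured and on what is new or still open speak of the compounds shown alone.

Of the compounds shown here, two have so far been tested in an ADME assay on J774.1 cells (Mus musculus) for cytotoxicity, with a stated time of 48 h; on this read-out higher numbers stand for an effect only at larger amounts of compound and lower numbers for an effect already at smaller amounts. For compound 1 `C=CCN1[C@H](c2ccccc2)C(C(=O)OC)C(=O)C(C(=O)OC)[C@@H]1c1ccccc1` the assay reports only a limit, > 100 uM. Within the data shown here, compound 2 `C=CCN1[C@H](c2ccc([N+](=O)[O-])cc2)C(C(=O)OC)C(=O)C(C(=O)OC)[C@@H]1c1ccc([N+](=O)[O-])cc1` gives 50.3 uM in this assay, the one actual number in this set. The other entry belongs to compound 1 and is a limit: the limit of > 100 uM in this assay, at which 1 of the 2 values shown sits. Compound 3 `COC(=O)C1C(=O)C(C(=O)OC)[C@H](c2ccc([N+](=O)[O-])cc2)N(Cc2ccccc2)[C@@H]1c1ccc([N+](=O)[O-])cc1` differs from compound 2 by phenyl in place of vinyl on a saturated chain carbon bound to an amine nitrogen in a ring. Among the measured compounds shown here, no measured pair of compounds differs in one place, so nothing here shows how such a change moves this read-out. The step of a 1.1-fold lower number from compound 2 to compound 3 (0.05 log units; within the scatter) is expected to stay within the usual scatter. Compound 3 is therefore estimated at 45 uM, in the range 15 uM to 100 uM.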

Compound 3, concentration for half-maximal effect: 18.4 uM
The estimate for compound 3 lay 2.4-fold (0.39 log units) above the measured number, within the range that was stated.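

Among these compounds, this is the first pair of compounds differing in one place, and it shows that this position affects the read-out: allyl to benzyl gives a 2.7-fold lower number from compound 2 to compound 3 (0.44 log units; beyond the scatter) in this assay. Cytotoxicity therefore appears at smaller amounts of compound with benzyl than with allyl in this pair. Nothing available explains why the number moves.

From the compounds shown here alone, whether a longer chain, an amine or a carboxylic acid at this place would raise or lower the number remains open. So does whether benzyl would act in the same way on the core of compound 1.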